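Hydrogen in Place of Methoxy: What to Expect

This account rests on a few compounds, and the source may have more. Where it says the series, first, only, none or still open, it means among the compounds named here.

For the measured compounds named here, compound 1 `COc1ccc(-c2ccc(-c3ccc(C(=N)N)o3)o2)cc1` gives the lowest number of the two compounds measured so far: in a functional assay on MDA-MB-468 cells (Homo sapiens) for inhibition, read by sulforhodamine B assay, with a stated time of 48 h (on this read-out higher numbers stand for weaker inhibition of growth and lower numbers for stronger inhibition of growth), compound 1 gives 860 nM. Compound 2 `N=C(N)c1ccc(-c2ccc(-c3cncc4ccccc34)s2)s1` sits close by; in this assay compound 2 gives 1270 nM, and the gap between the two lies within the scatter of the measurement, so no order between them can be claimed. Compound 3 `N=C(N)c1ccc(-c2ccc(-c3ccccc3)o2)o1` has not yet been measured. It differs from compound 1 in a single place: hydrogen in place of methoxy on an aromatic carbon. Going by the values given here, no step between measured compounds of this kind is available, so the size of the change can only be anticipated. In this assay a step of about a 1.5-fold higher number from compound 1 to compound 3 (0.18 log units; within the scatter) is expected, leaning toward a modestly higher number rather than a lower one. Compound 3 is therefore estimated at 1300 nM, within a range of 450 nM to 3800 nM.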

Compound 3, concentration for 50% growth inhibition: 1640 nM
Beside the measured number, compound 3's estimate is 1.3-fold (0.10 log units) below it, and the stated range covers the measured number.
By their numbers in this assay, from the lowest: compounds 1, 2 and 3 (each within the scatter of the next).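

In this assay, hydrogen in place of methoxy on an aromatic carbon gives a 1.9-fold higher number from compound 1 to compound 3 (0.28 log units; within the scatter) as the first step read at this position. The methoxy group, with its one hydrogen-bond acceptor, can therefore give way to hydrogen at this place, para to a large group, without a change that can be told from the scatter of the measurement. Nothing among the data shown offers an explanation for the size of this step.

As far as these compounds go, whether another group at this place, such as an amine, a carboxylic acid or a longer alkoxy chain, would shift the number beyond the scatter remains open. From the compounds shown here alone, it is also open whether hydrogen in place of methoxy would give a step of similar size on a core other than that of compound 1.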